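The source may hold more compounds than are shown below. What is called first, only, known or untested is meant among the compounds shown, and "the series" means these compounds.

In an in vivo ADME assay on the whole organism (plasma) for pharmacokinetics, with Rattus norvegicus as the target, at a dose of 50 mg/kg by the oral route (a higher number here means more compound in the circulation at the dose given, a lower number less compound in the circulation), compound 1 (`CC(=O)OCc1c(C)cc(C)c(NC(=O)c2sccc2S(=O)(=O)Nc2onc(C)c2Cl)c1C`) gives 7420 nM and stands level with the two other measured compounds. Compound 2 (`COc1c(C)cc(C)c(NC(=O)c2sccc2S(=O)(=O)Nc2onc(C)c2Cl)c1C`) gives 8510 nM and compound 3 (`Cc1cc(C)c(OC2CC2)c(C)c1NC(=O)c1sccc1S(=O)(=O)Nc1onc(C)c1Cl`) gives 12300 nM on the same core. Compound 4 (`Cc1cc(C)c(NS(C)(=O)=O)c(C)c1NC(=O)c1sccc1S(=O)(=O)Nc1onc(C)c1Cl`) has methanesulfonamido in place of acetoxymethyl on an aromatic carbon and has not yet been measured. Three measured changes bear on this place, with a 1.1-fold higher number from compound 1 to compound 2 (0.06 log units; within the scatter) for methoxy, a 1.7-fold higher number from compound 1 to compound 3 (0.22 log units; within the scatter) for cyclopropyloxy and a 1.4-fold higher number from compound 2 to compound 3 (0.16 log units; within the scatter) between those two. Among the compounds with values here, no measured compound carries methanesulfonamido, so the evidence is indirect. The expected change is small (a 1.1-fold lower number from compound 1 to compound 4 (0.06 log units; within the scatter)) and no step beyond the scatter is expected in this assay here. For compound 4 the estimate is 6500 nM and repeat measurements are expected to fall between 2000 nM and 15000 nM in most cases.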

Compound 4, maximal plasma concentration: 5250 nM
Beside the measured number, compound 4's estimate is 1.2-fold (0.09 log units) above it; the range from low to high includes it.
By their numbers in this assay, from the lowest: compounds 4, 1, 2 and 3 (each within the scatter of the next, the first and the last beyond it).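

Within the data shown here, at this position, methanesulfonamido gives the first step beyond the scatter in this assay, a 2.3-fold lower number from compound 3 to compound 4 (0.37 log units; beyond the scatter), and that step is modest. The other two steps, a 1.4-fold lower number from compound 1 to compound 4 (0.15 log units; within the scatter) and a 1.6-fold lower number from compound 2 to compound 4 (0.21 log units; within the scatter), stay within the scatter, so the new group separates only from cyclopropyloxy. Nothing available accounts for this separation. The compounds shown leave open whether an amine or a carboxylic acid on this aromatic carbon would move the number further from those of compound 1 and compound 2. They also leave open what a longer chain on the sulfonyl group would do.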